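Methoxy to hydroxy on the dimethylamino-bearing analogue

This account rests on a few compounds, and the source may have more. Where it says the series, first, only, none or still open, it means among the compounds named here.

Two compounds of the series have been run in a functional assay on TK-10 cells (Homo sapiens) for cytotoxicity, read by sulforhodamine B assay, with a stated time of 48 h, tested at 0.001 uM; on this read-out lower numbers stand for a stronger effect and higher numbers for a weaker effect at the one concentration tested. Compound 1 `Cc1cc(O)cc(-c2nn(CC#N)cc2-c2ccnc(-c3ccc(Oc4ccccc4)cc3)c2)c1` carries a hydroxy on its pendant aryl ring and in this assay gives 91%. Compound 2 `COc1cc(C)cc(-c2nn(CC#N)cc2-c2ccnc(-c3ccc(N(C)C)cc3)c2)c1` carries a methoxy in that position together with a dimethylamino-substituted aryl on the other side of the core, and in this assay compound 2 gives 109%, the higher of the two numbers; the gap to compound 1 lies beyond the usual scatter. The two differ in more than one place, so the gap cannot be assigned to either change.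

Compound 3 `Cc1cc(O)cc(-c2nn(CC#N)cc2-c2ccnc(-c3ccc(N(C)C)cc3)c2)c1` is the next member: hydrogen in place of methyl on an oxygen on an aromatic ring. The change joins the hydroxy of compound 1 to the remainder of compound 2. With compound 1 at 91% and compound 2 at 109%, a small downward step is expected, a number 9 percentage points lower from compound 2 to compound 3 (within the scatter), but not one that clearly exceeds the scatter. In this assay compound 3 is therefore estimated at 100%, with a range from 85% to 115%.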

Compound 3, a percentage reported as activity, at one concentration (the size of the read-out at that concentration, not a potency): 105%
Estimate against measurement, compound 3: 5 percentage points below; low and high end bracket the measured number.
By their numbers in this assay, from the lowest: compound 1; then compounds 3 and 2 (each within the scatter of the next).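

In this assay the change from methoxy to hydroxy, which turns 3-methoxy-5-methylphenyl into 3-hydroxy-5-methylphenyl, can now be read on its own, and the step is a number 4 percentage points lower from compound 2 to compound 3 (within the scatter) so with the dimethylamino group in place, hydrogen in place of methyl on this oxygen gives no readable difference at the one concentration tested. Within the data shown here, with the hydroxy held constant, the other side of the core can also be read alone: dimethylamino in place of phenoxy on an aromatic carbon gives a number 14 percentage points higher from compound 1 to compound 3 (beyond the scatter) and is the only single-place step so far to exceed the scatter. No measurement at hand bears on the reason for either step.

From the compounds shown here alone, it remains open whether methoxy and hydroxy would also read alike with phenoxy in place of dimethylamino, so the two changes cannot yet be tested for independence. Also open, going by these compounds, is how an amine or a carboxylic acid on this aromatic position would read, and whether any of these steps would hold at other concentrations.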